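The compounds below may be only part of what the source reports. "The series", "measured", "known", "first", "only" and "open" are said of these compounds alone.

Of the compounds shown here, two have so far been tested in an assay on microsomes from liver for inhibition of acyl-CoA desaturase 1 (Rattus norvegicus); a higher number here means a weaker inhibitor, a lower number a stronger inhibitor. Compound 1, `FC(F)(F)c1ccccc1OC1CCN(c2ccc(-c3nnco3)nn2)CC1`, gives 22 nM in this assay. Compound 2, `CC(=O)c1ccccc1OC1CCN(c2ccc(-n3ccnc3)nn2)CC1`, gives 34 nM in this assay, the higher of the two numbers, though the gap to compound 1 lies within the usual scatter, so neither can be called the stronger inhibitor. Compound 3, `Brc1cccc(OC2CCN(c3ccc(-n4ccnc4)nn3)CC2)c1`, awaits measurement. It differs from compound 2 in one place: 3-bromophenyl in place of 2-acetylphenyl on an oxygen on a saturated carbon. Going by the values given here, no measured pair shows this kind of change, so only a small step is expected, near the scatter, leaning if anything toward a higher number. Compound 3 is therefore expected to give about 50 nM, within 15 nM to 170 nM, an expected step of a 1.5-fold higher number from compound 2 to compound 3 (0.17 log units; within the scatter).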

Compound 3, half-maximal inhibitory concentration: 23 nM
Estimate against measurement, compound 3: 2.2-fold (0.34 log units) above; low and high end bracket the measured number.
By their numbers in this assay, from the lowest: compounds 1, 3 and 2 (each within the scatter of the next).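

In this assay, 3-bromophenyl can stand in place of 2-acetylphenyl on the oxygen with a 1.5-fold lower number from compound 2 to compound 3 (0.17 log units; within the scatter). This swap removes the carbonyl, the only hydrogen-bond acceptor in the group, yet the number stays within the scatter, so this pair shows no need for that acceptor at this position. No measurement here explains this result. The pair also changes the group's identity and its place on the phenyl ring together, leaving those two effects unseparated. On these data alone, how a carboxylic acid or an amine on that phenyl ring would fare remains open.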